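A few compounds are considered here, and "the series" means these few. Any claim that something is new, unique, unknown or untested is made for them only; others in the source may bear on it.

Of the compounds shown here, three built on one shared core have been measured, and a fourth awaits its result. Compound 1 `Cc1nn(C)c(Oc2cccc(F)c2)c1/C=N\CCCCCOc1cc2oc(=O)cc(C)c2cc1Cl`, compound 2 `Cc1nn(C)c(Oc2ccc(Cl)cc2)c1/C=N\CCCCCOc1cc2oc(=O)cc(C)c2cc1Cl` and compound 3 `Cc1nn(C)c(Oc2ccc(F)cc2)c1/C=N\CCCCCCOc1cc2oc(=O)cc(C)c2cc1Cl` differ only in the halogenated phenyl group attached through an oxygen, and in the length of the chain leading to the coumarin-like part of the core. In a functional assay on SMMC-7721 cells (Homo sapiens) for antiproliferative activity, read by MTT assay, with a stated time of 72 h (a lower number here means a stronger inhibitor, a higher number a weaker inhibitor), compound 1 gives 11800 nM. In this assay compound 2 gives 17500 nM. In this assay compound 3 gives 13500 nM. All three numbers fall within the usual scatter of one another, so compound 3 cannot be set apart from its two relatives on these data.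

Compound 4 `Cc1nn(C)c(Oc2ccccc2Br)c1/C=N\CCCCCCOc1cc2oc(=O)cc(C)c2cc1Cl` is the next member. It differs from compound 3 in one place: 2-bromophenyl in place of 4-fluorophenyl on an oxygen on an aromatic ring. Among the measured compounds shown here, only one measured step bears on this kind of change, the swap of one halogenated phenyl for another on the same oxygen: a 1.5-fold higher number from compound 1 to compound 2 (0.17 log units; within the scatter). That step altered both the halogen and its position on the ring and still produced nothing beyond the scatter. The move from compound 3 to compound 4 is of the same sort, so no step beyond the scatter is expected; the expected step is a 1.0-fold higher number from compound 3 to compound 4 (0.02 log units; within the scatter). Compound 4 is therefore expected to give about 14000 nM, within a range from 6000 nM to 35000 nM.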

Compound 4, half-maximal inhibitory concentration: 19700 nM
Beside the measured number, compound 4's estimate is 1.4-fold (0.15 log units) below it; measured number inside the range.
By their numbers in this assay, from the lowest: compounds 1, 3, 2 and 4 (each within the scatter of the next).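

In this assay, putting 2-bromophenyl in place of 4-fluorophenyl on the oxygen gives a 1.5-fold higher number from compound 3 to compound 4 (0.16 log units; within the scatter) and so stays within the usual scatter of repeated measurements. This step brings in something the earlier compounds did not have: a bromine, the largest of the halogens shown here by atom, in a phenyl group named as 2-substituted, whereas the earlier phenyl groups carry fluorine or chlorine and are named differently. Even with both the halogen and its place on the phenyl ring altered, the result in this series is a second such swap that cannot be told apart from no difference at all, and no measurement at hand offers an explanation for the small gap that remains.

On these data alone, all four groups on this oxygen are halogenated phenyl rings, so it remains open whether a plain phenyl, a methoxyphenyl or an aminophenyl group would give a number clearly apart from these. No pair shown differs in chain length alone, so the effect of the chain cannot be read, and a shorter or longer chain remains an open question too.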